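The compounds below may be only part of what the source reports. "The series", "measured", "known", "first", "only" and "open" are said of these compounds alone.

Compound 1 has the structure `CC1CCN(C2CCN(S(=O)(=O)c3cccc(-c4ccccc4C(F)(F)F)c3)CC2)CC1`; in a functional assay on DLD-1 cells (Homo sapiens) for antiproliferative activity, read by CellTiter-Glo, with a stated time of 72 h (a lower number here means a stronger inhibitor, a higher number a weaker inhibitor), compound 1 gives 10 nM. Compound 2 has the structure `CC1CCN(C2CCN(S(=O)(=O)c3cn(C)cn3)CC2)CC1`; for compound 2 the result is a limit of the assay, > 5000 nM. Compound 3 has the structure `CC1CCN(C2CCN(S(=O)(=O)c3ccc(C(C)(C)C)cc3)CC2)CC1`; for compound 3 the result is likewise a limit, > 5000 nM.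

The shared core of all three is the same, and only the group on the sulfonyl sulfur changes. Compound 2, carrying the 1-methyl-1H-imidazol-4-yl group, stands at the limit of > 5000 nM in this assay, at which 2 of the 3 values shown sit, so no number is known for it, only that it lies beyond what this assay resolves. Compound 3, with a tert-butyl-substituted phenyl ring, stands at the same limit. Only compound 1, with its phenyl ring bearing a second phenyl with a trifluoromethyl group, gives a measured number.

Compound 4 has the structure `Cc1noc(C)c1S(=O)(=O)N1CCC(N2CCC(C)CC2)CC1`. It differs from compound 2 as follows: 3,5-dimethyl-1,2-oxazol-4-yl in place of 1-methyl-1H-imidazol-4-yl on a sulfonyl sulfur. One small five-membered aromatic ring with two hetero atoms is exchanged for another, both with two hydrogen-bond acceptors and no donors, and the bulky aromatic substituent that compound 1 carries is absent in both. Among the measured compounds shown here, no measured pair shows what such an exchange does here. The expected step that the limit leaves unreadable from compound 2 to compound 4 is therefore none beyond the usual scatter, and compound 4 is expected most likely to remain at the limit. Compound 4 is estimated at 6000 nM, with a range from 1500 nM to 20000 nM.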

Compound 4, half-maximal inhibitory concentration: > 5000 nM
Compound 4: no number, only a limit (the forecaster's own chance of this, stated with the estimate: 70%); the middle value lies beyond the limit too.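

Compound 2 and compound 4 both give only a limit in this assay, not a number, so no step can be read between them. The compounds shown leave open how far beyond that limit either compound lies, and which feature of the group on the sulfonyl sulfur sets compound 1 apart from compounds 2, 3 and 4.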